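A few compounds are considered here, and "the series" means these few. Any claim that something is new, unique, unknown or untested is made for them only; others in the source may bear on it.

In a functional assay on MDA-MB-231 cells (Homo sapiens) for cytotoxicity, read by MTT assay, with a stated time of 48 h (on this read-out higher numbers stand for weaker inhibition and lower numbers for stronger inhibition), compound 1 (`Fc1cccc(-c2nc(Nc3ccc(Cl)cc3)c3cc(F)ccc3n2)c1`) reads > 50000 nM as a limit of the assay. Compound 2 (`Cc1cccc(Nc2nc(-c3cccc(F)c3)nc3ccc(F)cc23)c1`) stands at > 50000 nM and this too is only a limit. The evidence so far is the limit of > 50000 nM in this assay, at which 2 of the 2 values shown sit, and nothing finer. For the measured compounds named here, the one measured step is a step that the two limits leave unreadable from compound 1 to compound 2 and it gives no size to carry over. Compound 3 (`Cc1ccccc1Nc1nc(-c2cccc(F)c2)nc2ccc(F)cc12`) carries 2-methylphenyl in place of 3-methylphenyl on a nitrogen on an aromatic ring. No step beyond the scatter is expected, and the estimated step is a number no higher from compound 2 to compound 3 (the limit leaves the size open) with no direction foreseen. Compound 3 is estimated at 50000 nM with an expected range of 20000 nM to 80000 nM in this reading.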

Compound 3, half-maximal inhibitory concentration: > 50000 nM
Compound 3: no number, only a limit (the forecaster's own chance of this, stated with the estimate: 75%); the middle value sits exactly at the limit.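

For the compounds shown here, compound 1, compound 2 and compound 3 each give only a limit in this assay, and no step among them can be read. The compounds shown leave open how far each lies beyond that limit and whether any group on the nitrogen changes the read-out: the limit of > 50000 nM in this assay, at which 3 of the 3 values shown sit.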